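A trifluoromethyl step from compound 3 to compound 4

The source may report more compounds than this note shows. Statements on the series, on what has been measured and on what is new or still open speak of the compounds shown alone.

In a functional assay on SMMC-7721 cells (Homo sapiens) for cytotoxicity, read by MTT assay, with a stated time of 24 h (a higher number here means a weaker inhibitor, a lower number a stronger inhibitor), compound 1 (`O=C1/C(=C/c2cccnc2)CN(S(=O)(=O)c2ccccc2)C/C1=C\c1ccccc1C(F)(F)F`) gives 10900 nM, compound 2 (`O=C1/C(=C/c2cccnc2)CN(S(=O)(=O)c2ccc(C(F)(F)F)cc2)C/C1=C\c1ccccc1C(F)(F)F`) gives 1730 nM and compound 3 (`O=C1/C(=C/c2ccncc2)CN(S(=O)(=O)c2ccccc2)C/C1=C\c1ccccc1C(F)(F)F`) gives 6540 nM. Compound 3 thus lies within the scatter of compound 1, and its number is higher than that of compound 2. Compound 4 (`O=C1/C(=C/c2ccncc2)CN(S(=O)(=O)c2ccc(C(F)(F)F)cc2)C/C1=C\c1ccccc1C(F)(F)F`) carries trifluoromethyl in place of hydrogen on an aromatic carbon, para to a large group: trifluoromethyl in place of hydrogen on an aromatic carbon. For the measured compounds named here, the same change produced a 6.3-fold lower number from compound 1 to compound 2 (0.80 log units; beyond the scatter), the only direct precedent. The exchange of pyridin-3-yl for pyridin-4-yl gave a 1.7-fold lower number from compound 1 to compound 3 (0.22 log units; within the scatter). A similar modest drop is therefore expected in this assay, and the expected step is a 6.3-fold lower number from compound 3 to compound 4 (0.80 log units; beyond the scatter). Compound 4 is estimated at 1040 nM, with an expected range from 450 nM to 2500 nM.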

Compound 4, half-maximal inhibitory concentration: 3840 nM
Beside the measured number, compound 4's estimate is 3.7-fold (0.57 log units) below it; measured number outside the range, above it.
By their numbers in this assay, from the lowest: compound 2; then compounds 4, 3 and 1 (each within the scatter of the next, the first and the last beyond it).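

In this assay, trifluoromethyl in place of hydrogen gives a 1.7-fold lower number from compound 3 to compound 4 (0.23 log units; within the scatter), so the size of this change depends on which pyridinyl group the compound carries: the same change on two cores in this assay, a 6.3-fold lower number (0.80 log units; beyond the scatter) from compound 1 to compound 2 and a 1.7-fold lower number (0.23 log units; within the scatter) from compound 3 to compound 4, 3.7-fold (0.57 log units) apart, beyond the scatter of two such steps. Pyridin-4-yl in place of pyridin-3-yl likewise depends on the other group, giving a 2.2-fold higher number from compound 2 to compound 4 (0.35 log units; beyond the scatter) once trifluoromethyl is present: the same change on two cores in this assay, a 1.7-fold lower number (0.22 log units; within the scatter) from compound 1 to compound 3 and a 2.2-fold higher number (0.35 log units; beyond the scatter) from compound 2 to compound 4, 3.7-fold (0.57 log units) apart, beyond the scatter of two such steps. Across these four compounds, the two changes therefore do not add independently. The compounds shown leave open how a nitrile, a methoxy group or an amine on that aromatic carbon would behave with either pyridinyl group.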